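A few compounds are considered here, and "the series" means these few. Any claim that something is new, unique, unknown or untested is made for them only; others in the source may bear on it.

In a functional assay on HT-29 cells (Homo sapiens) for antiproliferative activity, read by sulforhodamine B assay, with a stated time of 48 h (on this read-out lower numbers stand for stronger inhibition and higher numbers for weaker inhibition), three compounds that share one core differ only in the group on the sulfonamide nitrogen. Compound 1 `CCc1ccccc1NS(=O)(=O)c1ccc(N2CCNC2=O)cc1` gives 240 nM, compound 2 `Cc1ccc(NS(=O)(=O)c2ccc(N3CCNC3=O)cc2)cc1` gives 480 nM, and compound 3 `O=C1NCCN1c1ccc(S(=O)(=O)Nc2ccc(Cl)cc2)cc1` gives 220 nM. Compound 3 has the lowest of the three numbers, yet its gap to compound 1 is within the scatter, so the two cannot be ranked; only the gap to compound 2 is beyond it, as a 2.2-fold lower number from compound 2 to compound 3 (0.34 log units; beyond the scatter) shows.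

Compound 4 `COc1ccc(NS(=O)(=O)c2ccc(N3CCNC3=O)cc2)cc1` is not yet measured. It differs from compound 3 by methoxy in place of chloro on an aromatic carbon, on an aromatic carbon para to a large group. Among the measured compounds shown here, the one measured step at that position is a 2.2-fold lower number from compound 2 to compound 3 (0.34 log units; beyond the scatter), a modest change. Nothing shows methoxy itself. Taking methoxy to behave more like methyl than like chloro, a modest upward step, a 1.8-fold higher number from compound 3 to compound 4 (0.26 log units; within the scatter), is expected, though a result within the scatter would not surprise. Compound 4 is therefore estimated at 400 nM, in a range from 180 nM to 900 nM.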

Compound 4, half-maximal inhibitory concentration: 800 nM
Estimate against measurement, compound 4: 2.0-fold (0.30 log units) below; measured number inside the range.
By their numbers in this assay, from the lowest: compounds 3, 1, 2 and 4 (each within the scatter of the next, the first and the last beyond it).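

In this assay, methoxy in place of chloro, para to a large group, gives a 3.6-fold higher number from compound 3 to compound 4 (0.56 log units; beyond the scatter), so this position responds to a second exchange, and the response is again beyond the scatter. Methoxy in place of methyl gives a 1.7-fold higher number from compound 2 to compound 4 (0.22 log units; within the scatter), which is within the scatter, so those two groups cannot be ranked here, and chloro alone stands apart with the lower number. The 4-methoxyphenyl group also separates from the 2-ethylphenyl group, with a 3.3-fold higher number from compound 1 to compound 4 (0.52 log units; beyond the scatter), a gap that compound 2 did not show beyond the scatter.

Nothing here gives a measured reason why chloro differs from methyl and methoxy. From the compounds shown here alone, whether a fluoro group, an amine or a carboxylic acid at this position would fall with chloro or with methyl and methoxy remains open.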